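Furan-2-yl in place of phenyl: the step to compound 4

This account rests on a few compounds, and the source may have more. Where it says the series, first, only, none or still open, it means among the compounds named here.

In a functional assay on NCI-H1975 cells (Homo sapiens) for antiproliferative activity, read by MTT assay, with a stated time of 48 h (a lower number here means a stronger inhibitor, a higher number a weaker inhibitor), compound 3 (`O=C(c1ccc2[nH]c(-c3ccccc3)nc2c1)N1CCC2(CC1)CC(=O)N(c1ccc(C(F)(F)F)cc1)C2`) reads 380 nM and holds the second highest of three numbers. Compound 2 (`CCCc1nc2cc(C(=O)N3CCC4(CC3)CC(=O)N(c3ccc(C(F)(F)F)cc3)C4)cc(C)c2[nH]1`) reads 270 nM and lies within the scatter of compound 3. Compound 1 (`COC(=O)c1ccc(N2CC3(CCN(C(=O)c4cc(C)c5[nH]ncc5c4)CC3)CC2=O)cc1`) reads 5640 nM and gives a much higher number than compound 3, a gap beyond the scatter.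

Compound 4 (`O=C(c1ccc2[nH]c(-c3ccco3)nc2c1)N1CCC2(CC1)CC(=O)N(c1ccc(C(F)(F)F)cc1)C2`) carries furan-2-yl in place of phenyl on an aromatic carbon of a five-membered aromatic ring with 2 nitrogen, between two ring nitrogen atoms. For the measured compounds named here, no two measured compounds differ in one place only, so the data hold no direct measure of this change. The expectation therefore starts from compound 3 at 380 nM and from the fact that one aromatic ring replaces another. No step beyond the scatter is expected in this assay, and neither direction is favoured. The estimated step of a 1.1-fold higher number from compound 3 to compound 4 (0.02 log units; within the scatter) stays within the scatter. Compound 4 is estimated at 400 nM with an expected range of 150 nM to 1100 nM as its reading.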

Compound 4, half-maximal inhibitory concentration: 720 nM
The estimate for compound 4 lay 1.8-fold (0.26 log units) below the measured number, and the stated range covers the measured number.
By their numbers in this assay, from the lowest: compounds 2, 3 and 4 (each within the scatter of the next, the first and the last beyond it); then compound 1.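

In this assay, furan-2-yl in place of phenyl gives a 1.9-fold higher number from compound 3 to compound 4 (0.28 log units; within the scatter), the first direct measure of a change on this aromatic carbon between two ring nitrogen atoms. The earlier compounds shown here differed in more than one place and could not isolate this position. Here, exchanging a six-membered aromatic ring of carbon only for a five-membered aromatic ring with 1 hetero atom, which also adds a hydrogen-bond acceptor, produces no step beyond the scatter, and no evidence here bears on the reason for this result.

Going by these compounds, what remains open is whether thiophen-2-yl or pyridin-2-yl would also stay within the scatter of compound 3, and whether an amine or a carboxylic acid on this carbon would do the same. It is also unknown whether this exchange would give a similar step with a different group in place of the trifluoromethyl-bearing phenyl ring of the shared core.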